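The source may hold more compounds than are shown below. What is called first, only, known or untested is meant among the compounds shown, and "the series" means these compounds.

Of the compounds shown here, three of a shared core have been measured in an assay for inhibition of Dihydrofolate reductase (Bos taurus), at pH 6.25; on this read-out higher numbers stand for higher potency (the scale is a negative logarithm) and lower numbers for lower potency. Compound 1, `CC1(C)N=C(N)N=C(N)N1c1ccccc1N`, gives 4.11. Compound 2, `CC1(C)N=C(N)N=C(N)N1c1ccccc1S`, gives 7.2. Compound 3, `CCc1ccccc1N1C(N)=NC(N)=NC1(C)C`, gives 4.02, the lowest of the three numbers; one of its steps is a number 0.09 log units lower from compound 1 to compound 3 (within the scatter), whereas the other, a number 3.18 log units lower from compound 2 to compound 3 (beyond the scatter), is large.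

Compound 4, `CC1(C)N=C(N)N=C(N)N1c1ccccc1C(F)(F)F`, has not yet been measured. It differs from compound 3 in one place: trifluoromethyl in place of ethyl on an aromatic carbon. Going by the values given here, no measured step exchanges an ethyl for a trifluoromethyl, so nothing bears on the change directly. The nearest comparisons are the steps leading into compound 3: a number 0.09 log units lower from compound 1 to compound 3 (within the scatter), which stayed within the scatter, and a number 3.18 log units lower from compound 2 to compound 3 (beyond the scatter), which was large. Since the entering trifluoromethyl carries no hydrogen-bond donors or acceptors, like the ethyl it replaces, a step within the scatter is expected in this assay, a number 0.08 log units higher from compound 3 to compound 4 (within the scatter). Compound 4 is therefore estimated at 4.1, within the range 3.5 to 4.8.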

Compound 4, logarithm of the reciprocal of the active concentration, log(1/C): 3.15
Estimate against measurement, compound 4: 0.95 log units above; the measured number lies below the stated range.
By their numbers in this assay, from the lowest: compound 4; then compounds 3 and 1 (each within the scatter of the next); then compound 2.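

In this assay this position separates two groups that both carry no hydrogen-bond donors or acceptors, with a number 0.87 log units lower from compound 3 to compound 4 (beyond the scatter) on trifluoromethyl replacing ethyl. The amino and ethyl compounds had stood within the scatter of each other, so their level might have seemed a floor for groups other than sulfanyl, but trifluoromethyl falls under it, with a number 0.96 log units lower from compound 1 to compound 4 (beyond the scatter) and, against the sulfanyl compound, a number 4.05 log units lower from compound 2 to compound 4 (beyond the scatter) as the widest step in the set. Nothing available explains why trifluoromethyl and ethyl differ here.

The compounds shown leave open whether the high number belongs to sulfanyl alone or would also be reached by a hydroxyl or a methylsulfanyl group at this position. They also leave open where a single chlorine or a methyl group would fall relative to ethyl and trifluoromethyl.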